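Swapping the urea end group of a quinoline-based antiproliferative

The compounds below may be only part of what the source reports. "The series", "measured", "known", "first", "only" and "open" are said of these compounds alone.

Compound 1 `CCN(CC)C(=O)NCCCC(C)Nc1cc(OC)cc2cccnc12` carries a diethylamino group on the carbonyl carbon of its urea. For the measured compounds named here, in a functional assay on CCRF-CEM cells (Homo sapiens), read by MTT assay, with a stated time of 72 h (on this read-out higher numbers stand for weaker inhibition and lower numbers for stronger inhibition), compound 1 gives 142000 nM, the highest of the three numbers measured so far; the two measured partners both sit well below it. Compound 2 `COc1cc(NC(C)CCCNC(=O)NCc2ccncc2)c2ncccc2c1` gives 2900 nM in this assay, and compound 3 `COc1cc(NC(C)CCCNC(=O)N(C2CCCCC2)C2CCCCC2)c2ncccc2c1` gives 13000 nM.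

Compound 4 `COc1cc(NC(C)CCCNC(=O)NC2CCCC2)c2ncccc2c1` has not yet been measured. Its difference from compound 1 is cyclopentylamino in place of diethylamino on a carbonyl carbon. Going by the values given here, this is a change at the same place as the one measured step: a 49-fold lower number from compound 1 to compound 2 (1.69 log units; beyond the scatter), a large move towards stronger inhibition. Compound 3 also differs from compound 1 at that carbonyl carbon, and its value is far lower than that of compound 1 as well, though that pair is not a single-point step in the data. Both comparisons point the same way, so a step in this assay from compound 1 to compound 4 towards a lower number is expected, though the cyclopentylamino group matches neither measured partner exactly, and its size is uncertain.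

The expected step is a 16-fold lower number from compound 1 to compound 4 (1.20 log units; beyond the scatter). For compound 4 the estimate in this assay is 9000 nM, with a likely range from 2000 nM to 40000 nM.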

Compound 4, half-maximal inhibitory concentration: 41000 nM
For compound 4 the middle estimate is 4.6-fold (0.66 log units) below the measured one, and the stated range ends below it.
By their numbers in this assay, from the lowest: compound 2; then compound 3; then compound 4; then compound 1.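

Swapping the group on this carbonyl carbon does not give one fixed gain. In this assay there is a 3.5-fold lower number from compound 1 to compound 4 (0.54 log units; beyond the scatter), far smaller than the earlier 49-fold lower number from compound 1 to compound 2 (1.69 log units; beyond the scatter), even though both new groups replace diethylamino at the same place. The choice of group on the amide-type nitrogen therefore still matters greatly, as cyclopentyl in place of (pyridin-4-yl)methyl gives a 14-fold higher number from compound 2 to compound 4 (1.15 log units; beyond the scatter), and no measurement here explains why the two groups differ so much.

The compounds shown leave open which part of the (pyridin-4-yl)methyl group goes with the stronger inhibition of compound 2: its ring nitrogen, its aromatic ring or the single carbon joining that ring to the amide-type nitrogen. A benzylamino group, which keeps the single carbon but has an all-carbon aromatic ring, would test the ring nitrogen directly in the same assay, while a cyclohexylamino group would show whether the size of the carbon ring alone moves the number far from that of compound 4.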